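Side-chain change from compound 2 to compound 3

The source may report more compounds than this note shows. Statements on the series, on what has been measured and on what is new or still open speak of the compounds shown alone.

Measured so far in a functional assay on MCF7 cells (Homo sapiens) for inhibition (a lower number here means a stronger inhibitor, a higher number a weaker inhibitor), as half-maximal inhibitory concentrations:
- compound 1 `CCCCCC[C@@]1(C)SC(=O)C=C1OCCCCCl` gives 8.6 ug/mL
- compound 2 `C#CCOC1=CC(=O)S[C@]1(C)CCCCCC` gives 21.9 ug/mL

Compound 2 has the higher of the two numbers and is the weaker inhibitor of the pair. Compound 3 `CCCCCC[C@@]1(C)SC(=O)C=C1OCC(=O)NCC(=O)O` is not yet measured. Its change is (carboxymethyl)carbamoyl in place of ethynyl on a saturated chain carbon bound to an oxygen on an unsaturated carbon. For the measured compounds named here, only one measured step bears on this place: a 2.5-fold higher number from compound 1 to compound 2 (0.41 log units; beyond the scatter), which is modest but beyond the scatter. That step does not involve the entering group, so the data fix the direction poorly. A step of similar modest size in this assay is expected, leaning tentatively towards a higher number. For compound 3 the estimated value is 35 ug/mL with an expected range from 10 ug/mL to 110 ug/mL in this assay. The estimate means an expected 1.6-fold higher number from compound 2 to compound 3 (0.20 log units; within the scatter) overall.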

Compound 3, half-maximal inhibitory concentration: 6.6 ug/mL
The estimate for compound 3 lay 5.3-fold (0.72 log units) above the measured number, outside the stated range (below it).
By their numbers in this assay, from the lowest: compounds 3 and 1 (each within the scatter of the next); then compound 2.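

In this assay, for the compounds shown here, the place on a saturated chain carbon bound to an oxygen on an unsaturated carbon accepts (carboxymethyl)carbamoyl, with its 7 heavy atoms and 2 hydrogen-bond donors, and the change from ethynyl gives a 3.3-fold lower number from compound 2 to compound 3 (0.52 log units; beyond the scatter) in the opposite direction to the one step known before. Replacing 3-chloropropyl with the same group gives a 1.3-fold lower number from compound 1 to compound 3 (0.11 log units; within the scatter) so these two dissimilar side chains cannot be told apart here, while ethynyl stands apart from both. Nothing available accounts for this pattern.

From the compounds shown here alone, whether the lower number of compound 3 relative to compound 2 depends on the terminal carboxylic acid, the amide or chain length alone stays open. A methyl ester or a primary amide at this place would begin to separate these features.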